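The compounds below may be only part of what the source reports. "The series", "measured", "known", "first", "only" and "open" are said of these compounds alone.

Compound 2, the structure `Cn1cc(-c2cnc3[nH]cc(-c4ccc(C#N)cc4)c3c2)cn1`, was measured in a physicochemical assay for solubility, read by LC-MS, in phosphate buffer, measured as thermodynamic solubility, with a stated time of 24 h, at pH 7.4 (on this read-out higher numbers stand for higher solubility and lower numbers for lower solubility), and gave 2000 nM. Compound 1, the structure `Cn1cc(-c2cnc3[nH]cc(-c4ccnc(C#N)c4)c3c2)cn1`, gave 2000 nM in this assay, level with compound 2 at the digits printed and within the scatter of it; together these two are the lowest of the three numbers. Compound 3, the structure `Cn1cc(-c2cnc3[nH]cc(-c4ccc(F)c(F)c4)c3c2)cn1`, gave 5000 nM in this assay, a number that stands beyond the scatter away from compound 2.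

Compound 4, the structure `Cn1cc(-c2cnc3[nH]cc(-c4ccc(C(=O)O)cc4)c3c2)cn1`, has not yet been measured. It differs from compound 2 in one place: carboxy in place of cyano on an aromatic carbon of a six-membered aromatic ring of carbon only, para to a large group. Among the measured compounds shown here, no measured pair in this set shows a change of this kind, so no direct comparison is available. The expectation is that the step of a 10-fold higher number from compound 2 to compound 4 (1.00 log units; beyond the scatter) will point upward and exceed the scatter. On that basis compound 4 is estimated at 20000 nM in this assay, with a range from 5000 nM to 100000 nM.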

Compound 4, solubility: 850000 nM
Estimate against measurement, compound 4: 43-fold (1.63 log units) below; measured number outside the range, above it.
By their numbers in this assay, from the lowest: compounds 1 and 2 (each within the scatter of the next); then compound 3; then compound 4.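

In this assay, carboxy in place of cyano on an aromatic carbon, para to a large group, gives a 430-fold higher number from compound 2 to compound 4 (2.63 log units; beyond the scatter), a large step well beyond the scatter. Among the compounds shown here, the earlier compounds offered no comparison of a single change, so this is the first sign that one substituent at this position can move the read-out so far. The data given here offer nothing that accounts for the size of the step.

Going by these compounds, it remains open whether other groups at this position, such as an amine, a primary amide or a methyl ester, would give a step of similar size. On these data alone, it also remains open whether a carboxylic acid in place of the cyano group of compound 1, on that compound's own aromatic ring, would give a step like the one seen here.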